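Fluorine scan on the aryl-bearing ring carbon

The source may hold more compounds than are shown below. What is called first, only, known or untested is meant among the compounds shown, and "the series" means these compounds.

Measured so far:
- compound 1 `C#CC(=O)N1C(c2cccc(F)c2)SC[C@@H]1C(=O)OCC`: 1400 nM
- compound 2 `C#CC(=O)N1C(C(CC)CCCC)SC[C@@H]1C(=O)OCC`: 1700 nM
- compound 3 `C#CC(=O)N1C(c2ccccc2)SC[C@@H]1C(=O)OCC`: 5300 nM

In a functional assay on Huh-7 cells (Homo sapiens) for inhibition, read by sulforhodamine B assay (a higher number here means a weaker inhibitor, a lower number a stronger inhibitor), compound 3 stands highest of the three numbers, with a 3.8-fold higher number from compound 1 to compound 3 (0.58 log units; beyond the scatter) and a 3.1-fold higher number from compound 2 to compound 3 (0.49 log units; beyond the scatter) both beyond the scatter. Compound 4 `C#CC(=O)N1C(c2ccccc2F)SC[C@@H]1C(=O)OCC` differs from compound 3 by fluoro in place of hydrogen on an aromatic carbon, placed on an aromatic carbon of a six-membered aromatic ring of carbon only, ortho to a large group. Going by the values given here, the only measured step bearing on it is the reverse of a 3.8-fold higher number from compound 1 to compound 3 (0.58 log units; beyond the scatter), where the fluoro sat on a different aromatic carbon; no step with fluoro at this place exists. A modest step downward is expected in this assay, a 2.1-fold lower number from compound 3 to compound 4 (0.33 log units; beyond the scatter). Compound 4 is estimated at 2500 nM, in the range 900 nM to 7000 nM.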

Compound 4, half-maximal inhibitory concentration: 1700 nM
For compound 4 the middle estimate is 1.5-fold (0.17 log units) above the measured one; measured number inside the range.
By their numbers in this assay, from the lowest: compounds 1, 2 and 4 (each within the scatter of the next); then compound 3.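

In this assay, going by these compounds alone, 2-fluorophenyl in place of phenyl shows that fluoro at this place also shifts the number (a 3.1-fold lower number from compound 3 to compound 4 (0.49 log units; beyond the scatter)), a shift earlier seen only with the 3-fluorophenyl group. The two fluoro placements are not separated (a 1.2-fold higher number from compound 1 to compound 4 (0.08 log units; within the scatter)), and the 2-fluorophenyl group is likewise not separated from 1-ethylpentyl (no change at the digits printed from compound 2 to compound 4 (within the scatter)). No measurement at hand explains the effect of fluoro at either place.

Going by these compounds, whether chloro, methoxy or an amine in place of this fluoro would hold the number remains open. So does whether a second fluoro on the same aromatic ring would extend the step.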